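Formyl to acetyl on the aryl group of compound 2

A few compounds are considered here, and "the series" means these few. Any claim that something is new, unique, unknown or untested is made for them only; others in the source may bear on it.

Compound 1 `COc1ccc(-c2cn3ccnc3c(-c3ccc4ncn(C5CCCCC5)c4c3)n2)cc1` and compound 2 `O=Cc1ccc(-c2cn3ccnc3c(-c3ccc4ncn(C5CCCCC5)c4c3)n2)cc1` share one core. In a functional assay on ACHN cells (Homo sapiens) for inhibition, read by sulforhodamine B assay, with a stated time of 48 h, tested at 10 uM (on this read-out lower numbers stand for less inhibition and higher numbers for more inhibition at the one concentration tested (going by the name of the read-out)), compound 1 gives 61%, while compound 2 gives 11.6%, the lower of the two numbers; the change of a number 49.4 percentage points lower from compound 1 to compound 2 (beyond the scatter) lies beyond the scatter. Compound 3 `CC(=O)c1ccc(-c2cn3ccnc3c(-c3ccc4ncn(C5CCCCC5)c4c3)n2)cc1` differs from compound 2 by methyl in place of hydrogen on a carbonyl carbon. Among the compounds with values here, no measured step covers this change, so the expected step of a number 6.4 percentage points higher from compound 2 to compound 3 (within the scatter) is small, within the scatter, with a wide range. Compound 3 is therefore estimated at 18%, between 0% and 45%.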

Compound 3, a percentage reported as inhibition, at one concentration (the size of the read-out at that concentration, not a potency): 4.32%
The estimate for compound 3 lay 13.7 percentage points above the measured number; low and high end bracket the measured number.
By their numbers in this assay, from the lowest: compounds 3 and 2 (each within the scatter of the next); then compound 1.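

Methyl in place of hydrogen on the carbonyl carbon gives a number 7.3 percentage points lower from compound 2 to compound 3 (within the scatter) in this assay, so acetyl and formyl cannot be told apart at this position. Acetyl in place of methoxy gives a number 56.7 percentage points lower from compound 1 to compound 3 (beyond the scatter) and thus stays as far from methoxy as formyl does, so the large gap is not peculiar to formyl. No available evidence accounts for the gap to methoxy. Still open, from the compounds shown here alone, is whether an amine, a carboxylic acid or a longer chain on the same aromatic carbon would reach the level of compound 1.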